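Second Ester Arm on the Amine: Weaker Inhibition Expected

The compounds below may be only part of what the source reports. "The series", "measured", "known", "first", "only" and "open" are said of these compounds alone.

Compound 2 `CCCCCCCCCCCCCCC(CNCC(=O)OCC)NC(=O)OC(C)(C)C` stands highest of the three measured numbers: in a functional assay on Jurkat cells (Homo sapiens) for inhibition (on this read-out lower numbers stand for stronger inhibition and higher numbers for weaker inhibition), compound 2 gives 28000 nM, while compound 1 `CCCCCCCCCCCCCCC(CN)NC(=O)OC(C)(C)C` gives 6000 nM and compound 3 `CCCCCCCCCCCCCCC(CNCCCCC(=O)O)NC(=O)OC(C)(C)C` gives 18000 nM. Compound 4 `CCCCCCCCCCCCCCC(CN(CC(=O)OCC)CC(=O)OCC)NC(=O)OC(C)(C)C` differs from compound 2 by (ethoxycarbonyl)methyl in place of hydrogen on an amine nitrogen. Among the compounds with values here, the closest precedent is a 4.7-fold higher number from compound 1 to compound 2 (0.67 log units; beyond the scatter), the same group added to the same nitrogen; a 3.0-fold higher number from compound 1 to compound 3 (0.48 log units; beyond the scatter) also weakened inhibition, whereas a 1.6-fold lower number from compound 2 to compound 3 (0.19 log units; within the scatter) compares two arms rather than adding one. Both additions to this nitrogen raised the number modestly, so a further rise is expected, estimated as a 2.5-fold higher number from compound 2 to compound 4 (0.40 log units; beyond the scatter). Compound 4 is therefore expected to give 70000 nM in this assay, with a range of 25000 nM to 200000 nM.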

Compound 4, half-maximal inhibitory concentration: > 60000 nM
Compound 4: only a limit was reported; the forecaster's own chance of this, stated with the estimate: 20%; the middle value lies beyond the limit too.
By their numbers in this assay, from the lowest: compound 1; then compounds 3 and 2 (each within the scatter of the next). At a limit, above all of these: compound 4.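

A second (ethoxycarbonyl)methyl on this amine nitrogen weakens inhibition again in this assay, with the step reading an at least 2.1-fold higher number from compound 2 to compound 4 (0.33 log units; beyond the scatter). Across compounds 1, 2 and 4, each added arm goes with a higher number, so this nitrogen shows no sign yet of accepting a second arm. Compound 4 has only a limit, not a true number, so the full size of this step stays unknown: the limit of > 60000 nM in this assay, at which 1 of the 4 values shown sits.

Still open, from the compounds shown here alone, is how a small methyl group on this nitrogen would read. Also open, going by these compounds, is whether carboxylic acids in place of the ethyl esters of compound 4 would change the number.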